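The source may hold more compounds than are shown below. What is called first, only, known or untested is meant among the compounds shown, and "the series" means these compounds.

Measured compounds:
compound 1, `CCNc1nc(C)c(-c2nc3ccccc3s2)c(N[C@@H]2C[C@H](CO)[C@@H](O)[C@H]2O)n1`; in an ADME assay on cells (Homo sapiens) for cytotoxicity, read by polymerase chain reaction, with a stated time of 3 days (on this read-out lower numbers stand for higher toxicity in this test and higher numbers for lower toxicity in this test), compound 1 gives 12000 nM.
compound 2, `Cc1nc(NCCNC(=O)NC(C)(C)C)nc(N[C@@H]2C[C@H](CO)[C@@H](O)[C@H]2O)c1-c1nc2ccccc2s1`; compound 2 reaches only a limit of this test, > 25000 nM.
compound 3, `Cc1nc(NCCC(F)(F)F)nc(N[C@@H]2C[C@H](CO)[C@@H](O)[C@H]2O)c1-c1nc2ccccc2s1`; compound 3 gives 9000 nM.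

Of the two plain numbers, compound 3 has the lowest, and the other belongs to compound 1. a 1.3-fold lower number from compound 1 to compound 3 (0.12 log units; within the scatter), so these two cannot be told apart. The value of compound 2 is a limit and sits at the limit of > 25000 nM in this assay, at which 1 of the 3 values shown sits.

Compound 4, `Cc1nc(Nc2ccccc2)nc(N[C@@H]2C[C@H](CO)[C@@H](O)[C@H]2O)c1-c1nc2ccccc2s1`, differs from compound 3 in one place: phenyl in place of 3,3,3-trifluoropropyl on a nitrogen on an aromatic ring. All measured steps sit further out, on a saturated chain carbon two bonds along the chain from the ring nitrogen: a 1.3-fold lower number from compound 1 to compound 3 (0.12 log units; within the scatter); an at least 2.0-fold higher number from compound 1 to compound 2 (0.31 log units; beyond the scatter); an at least 2.7-fold lower number from compound 2 to compound 3 (0.44 log units; beyond the scatter). Only the ((tert-butyl)carbamoyl)amino group moved the number beyond the scatter, toward lower toxicity; the trifluoromethyl change stayed within it. From the compounds shown here alone, replacing the whole chain by phenyl is untested here, so no step beyond the scatter is expected in either direction: the expected step is a 1.1-fold higher number from compound 3 to compound 4 (0.05 log units; within the scatter). Compound 4 is therefore estimated at 10000 nM, with a range from 4000 nM to 25000 nM.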

Compound 4, half-maximal cytotoxic concentration: > 25000 nM
Compound 4 was reported as a limit; the forecaster's own chance of this, stated with the estimate: 25%; at least 2.5-fold (0.39 log units) between middle value and limit.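

In this assay a phenyl group on this nitrogen gives an at least 2.7-fold higher number from compound 3 to compound 4 (0.44 log units; beyond the scatter) and an at least 2.0-fold higher number from compound 1 to compound 4 (0.31 log units; beyond the scatter) and so moves the number beyond the scatter, toward lower toxicity in this test. Among the earlier compounds, only the ((tert-butyl)carbamoyl)amino group had done that, so the chain of compound 2 is no longer the only change at this position that does so. Compound 4 gives only a limit, as does compound 2, so the step between them cannot be read: the limit of > 25000 nM in this assay, at which 2 of the 4 values shown sit.

The compounds shown leave open whether a benzyl group or a pyridyl ring on this nitrogen would also reach this limit. They also leave open whether a chlorine or a methoxy group on the phenyl would bring the number back down.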